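The compounds below may be only part of what the source reports. "The series", "measured", "known", "first", "only" and "open" are said of these compounds alone.

Three compounds built on one shared core differ only in the aryl group sitting on a double-bonded chain carbon bound to a double-bonded chain carbon and a saturated chain carbon. In a functional assay on MCF7 cells (Homo sapiens) for inhibition (on this read-out lower numbers stand for stronger inhibition and higher numbers for weaker inhibition), compound 1 `CC/C(=C(/c1ccc(/C=C/C(=O)O)cc1)c1cc2ccccc2[nH]1)c1ccccc1Cl` gives 42 nM, compound 2 `CC/C(=C(/c1ccc(/C=C/C(=O)O)cc1)c1cc2ccccc2[nH]1)c1ccc(OC)cc1` gives 61 nM, and compound 3 `CC/C(=C(/c1ccc(/C=C/C(=O)O)cc1)c1cc2ccccc2[nH]1)c1cccc(F)c1C#N` gives 40 nM. Compound 3 holds the lowest of the three numbers, yet the steps of a 1.1-fold lower number from compound 1 to compound 3 (0.02 log units; within the scatter) and a 1.5-fold lower number from compound 2 to compound 3 (0.18 log units; within the scatter) both lie within the scatter, so the three cannot really be separated. Compound 4 `CC/C(=C(/c1ccc(/C=C/C(=O)O)cc1)c1cc2ccccc2[nH]1)c1ccc(F)cc1Cl` carries 2-chloro-4-fluorophenyl in place of 2-cyano-3-fluorophenyl on a double-bonded chain carbon bound to a double-bonded chain carbon and a saturated chain carbon. The step that bears most directly on this change is a 1.1-fold lower number from compound 1 to compound 3 (0.02 log units; within the scatter), which swapped a 2-chlorophenyl for the 2-cyano-3-fluorophenyl without moving the number beyond the scatter; the step of a 1.5-fold higher number from compound 1 to compound 2 (0.16 log units; within the scatter) likewise stayed within it. Compound 4 returns to a chlorine-bearing phenyl while adding a fluorine, so in this assay no step beyond the scatter is expected, the estimated change being a 1.1-fold higher number from compound 3 to compound 4 (0.02 log units; within the scatter). Compound 4 is therefore estimated at 42 nM, with an expected range from 20 nM to 90 nM.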

Compound 4, half-maximal inhibitory concentration: 39 nM
For compound 4 the middle estimate is 1.1-fold (0.03 log units) above the measured one; measured number inside the range.
By their numbers in this assay, from the lowest: compounds 4, 3, 1 and 2 (each within the scatter of the next).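

For the compounds shown here, compound 4 gives the first pair here that differs only by fluoro in place of hydrogen on an aromatic carbon, and in this assay that single swap stays within the scatter (a 1.1-fold lower number from compound 1 to compound 4 (0.03 log units; within the scatter)). Replacing the nitrile-bearing 2-cyano-3-fluorophenyl or the 4-methoxyphenyl with 2-chloro-4-fluorophenyl also gives no readable change (a 1.0-fold lower number from compound 3 to compound 4 (0.01 log units; within the scatter); a 1.6-fold lower number from compound 2 to compound 4 (0.19 log units; within the scatter)), so all four aryl groups at this position remain within the scatter of one another, and nothing shown offers an explanation for that.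

The compounds shown leave open whether a saturated ring such as cyclohexyl, or a nitrogen-containing ring such as pyridyl, would give a similar number at this position. They also leave open whether any group here can move the number beyond the scatter.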